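Propyl for isopropyl on a second core: compound 4

The compounds below may be only part of what the source reports. "The series", "measured", "known", "first", "only" and "open" are said of these compounds alone.

Measured compounds:
- compound 1, `COc1cc(N(C)CCN(C)C)c(NC(=O)/C=C\C(C)C)cc1Nc1ncc(C#N)c(-c2cn(C)c3ccccc23)n1`: 1110 nM
- compound 2, `CCC/C=C\C(=O)Nc1cc(Nc2ncc(C#N)c(-c3cn(C)c4ccccc34)n2)c(OC)cc1N(C)CCN(C)C`: 823 nM
- compound 3, `COc1cc(N(C)CCN(C)C)c(NC(=O)/C=C\C(C)C)cc1Nc1nccc(-c2cn(C)c3ccc(F)cc23)n1`: 7360 nM

The three measured compounds were tested in a functional assay on NCI-H1975 cells (Homo sapiens) for antiproliferative activity, read by MTT assay, with a stated time of 72 h; a lower number here means a stronger inhibitor, a higher number a weaker inhibitor. Compound 1 `COc1cc(N(C)CCN(C)C)c(NC(=O)/C=C\C(C)C)cc1Nc1ncc(C#N)c(-c2cn(C)c3ccccc23)n1` gives 1110 nM there, and compound 2 `CCC/C=C\C(=O)Nc1cc(Nc2ncc(C#N)c(-c3cn(C)c4ccccc34)n2)c(OC)cc1N(C)CCN(C)C` gives 823 nM. The two differ by one change, (propyl in place of isopropyl on a double-bonded chain carbon bound to a double-bonded chain carbon), and the step between them is a 1.3-fold lower number from compound 1 to compound 2 (0.13 log units; within the scatter).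

Compound 3 `COc1cc(N(C)CCN(C)C)c(NC(=O)/C=C\C(C)C)cc1Nc1nccc(-c2cn(C)c3ccc(F)cc23)n1` stands apart from these two: in this assay compound 3 gives 7360 nM, the highest of the three numbers, with the gap to compound 1 and to compound 2 beyond the scatter. The difference between the core of compound 3 and the core of compound 1 is not broken down here.

Compound 4 `CCC/C=C\C(=O)Nc1cc(Nc2nccc(-c3cn(C)c4ccc(F)cc34)n2)c(OC)cc1N(C)CCN(C)C` has not yet been measured. It relates to compound 3 as compound 2 relates to compound 1: the change is propyl in place of isopropyl on a double-bonded chain carbon bound to a double-bonded chain carbon, the same change at the same place. Among the measured compounds shown here, the only guide to its size is the step observed from compound 1 to compound 2, which was within the scatter; on that basis the step expected from compound 3 to compound 4 is a 1.3-fold lower number from compound 3 to compound 4 (0.10 log units; within the scatter), a small one. For the measured compounds named here, compound 4 is therefore expected to give about 5800 nM in this assay, in a range from 2500 nM to 13000 nM, because compound 3 gives 7360 nM and the one earlier instance of this change moved the number only slightly.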

Compound 4, half-maximal inhibitory concentration: 2730 nM
Compound 4: middle estimate off by 2.1-fold (0.33 log units), on the high side, within the range that was stated.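

On the second core, propyl in place of isopropyl gives a 2.7-fold lower number from compound 3 to compound 4 (0.43 log units; beyond the scatter) in this assay. Set beside the earlier instance of this change, the new step cannot be told apart from it, so the two cores give no sign that the effect of this swap depends on the core: the same change on two cores in this assay, a 1.3-fold lower number (0.13 log units; within the scatter) from compound 1 to compound 2 and a 2.7-fold lower number (0.43 log units; beyond the scatter) from compound 3 to compound 4, 2.0-fold (0.30 log units) apart, within the scatter of two such steps Only the step on the second core lies beyond the scatter, but this does not show that the swap acts more strongly there, and two pairs of compounds establish no fixed size for the change and no rule for other cores in the series.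

The compounds shown leave open how this place on the chain responds to other groups, such as a longer chain like hexyl, a cyclopropyl ring or a terminal amine, since propyl and isopropyl are the only two groups compared here and both have the same count of heavy atoms. They also leave open whether the same swap would behave alike on a core carrying both the nitrile of compound 1 and the fluorine of compound 3.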